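The compounds below may be only part of what the source reports. "The series", "measured", "known", "first", "only" and "open" are said of these compounds alone.

Compound 1 `COc1cccc(CNc2ncnc3c2ncn3C2CCCCO2)c1` and compound 2 `COc1cc(CNc2ncnc3c2ncn3C2CCCCO2)cc(OC)c1` share one core, compound 2 carrying one further methoxy group; the change is methoxy in place of hydrogen on an aromatic carbon. In an ADME assay on MCF7 cells (Homo sapiens) for cytotoxicity, with a stated time of 72 h (on this read-out lower numbers stand for stronger inhibition and higher numbers for weaker inhibition), compound 1 gives 97000 nM. Compound 2 reaches only a limit of this assay, > 100000 nM. The step is an at least 1.0-fold higher number from compound 1 to compound 2 (0.01 log units; that floor lies within the scatter), resting on (the limit of > 100000 nM in this assay, at which 2 of the 3 values shown sit). Compound 3 `COc1ccc(CNc2ncnc3c2ncn3C2CCCO2)c(OC)c1` has another core; the difference between the two cores is not broken down here. Compound 3 likewise reaches only a limit in this assay, > 100000 nM. Compound 4 `COc1ccc(CNc2ncnc3c2ncn3C2CCCO2)c(OC)c1OC` remains to be measured and differs from compound 3 by methoxy in place of hydrogen on an aromatic carbon, the same kind of change as before, though here the entering group sits ortho to two methoxy groups and meta to a large group, whereas earlier it sat meta to a large group and meta to a methoxy group. The expected step is a step that the limit leaves unreadable from compound 3 to compound 4, because the matching earlier step gave an at least 1.0-fold higher number from compound 1 to compound 2 (0.01 log units; that floor lies within the scatter). Compound 4 is expected near 150000 nM, probably again only a limit, within 60000 nM to 400000 nM.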

Compound 4, half-maximal inhibitory concentration: > 100000 nM
Compound 4: no number, only a limit; the forecaster's own chance of this, stated with the estimate: 75%; the middle value does not contradict the limit.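

No step can be read between compound 3 and compound 4, because each gives only a limit and no number: the limit of > 100000 nM in this assay, at which 3 of the 4 values shown sit.

Going by these compounds, whether methoxy in place of hydrogen on an aromatic carbon shifts the read-out on the core of compound 3 stays open.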